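Chloro to trifluoromethyl: what inhibition to expect

This account rests on a few compounds, and the source may have more. Where it says the series, first, only, none or still open, it means among the compounds named here.

Compound 1, `O=S(=O)(c1ccccc1)c1ccc(O)nn1`, gives 14% in a functional assay on the whole organism for inhibition, with Rattus norvegicus as the target, with a stated time of 60 min, at pH 4.5, at a dose of 10 mg/kg by the oral route; a lower number here means a weaker effect, a higher number a stronger effect of the compound at the dose given. Compound 2, `O=S(=O)(c1ccc(Cl)cc1)c1ccc(O)nn1`, gives 52%. Compound 3, `O=S(=O)(c1ccc(Cl)c(Cl)c1)c1ccc(O)nn1`, gives 60%.

Among these three numbers compound 2 stands second highest; its nearest neighbour is compound 3, whose value lies within the scatter of its own, while compound 1 sits well below it, as the step of a number 38 percentage points higher from compound 1 to compound 2 (beyond the scatter) shows. Compound 4, `O=S(=O)(c1ccc(C(F)(F)F)cc1)c1ccc(O)nn1`, differs from compound 2 by trifluoromethyl in place of chloro on an aromatic carbon. Going by the values given here, no measured step exchanges chloro for another group; both known steps add chloro where hydrogen stood: a number 38 percentage points higher from compound 1 to compound 2 (beyond the scatter) was large, whereas a number 8 percentage points higher from compound 2 to compound 3 (within the scatter) stayed within the scatter. There is therefore no direct guide, and the expected step of no change at the digits printed from compound 2 to compound 4 (within the scatter) is modest, with no direction beyond the scatter. For compound 4 the estimated value in this assay is 52%, ranging from 30% to 72%.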

Compound 4, a percentage reported as inhibition, in the whole organism at one dose (the size of the read-out at that dose, not a potency): 10%
Compound 4: middle estimate off by 42 percentage points, on the high side; measured number outside the range, below it.
By their numbers in this assay, from the lowest: compounds 4 and 1 (each within the scatter of the next); then compounds 2 and 3 (each within the scatter of the next).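

Trifluoromethyl cannot stand in for chloro at this position in this assay, as the large step of a number 42 percentage points lower from compound 2 to compound 4 (beyond the scatter) takes away the gain that chloro brought. With hydrogen in that place instead, the step of a number 4 percentage points lower from compound 1 to compound 4 (within the scatter) shows that trifluoromethyl offers no difference from hydrogen beyond the scatter. Nothing available here accounts for this sharp difference between the two groups.

The compounds shown leave open how other groups at this position, such as bromo, methyl or methoxy, would behave. They also leave open whether a second group added to compound 4 would change its number, as a second chloro did not for compound 2.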